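This account rests on a few compounds, and the source may have more. Where it says the series, first, only, none or still open, it means among the compounds named here.

Measured so far in an assay on HEK293 cells for positive allosteric modulation of metabotropic glutamate receptor 5 (Homo sapiens), read by FLIPR, with a stated time of 1 h; on this read-out higher numbers stand for an effect only at larger amounts of compound and lower numbers for an effect already at smaller amounts:
compound 1, `O=C(C1CC1)N1CCc2nc(C#Cc3ccccc3)sc2C1`, gives > 10000 nM.
compound 2, `CC1CC1C(=O)N1CCc2nc(C#Cc3ccccc3)sc2C1`, gives 9.4 nM.

The value of compound 1 is a limit of this assay, not a number. Compound 2 therefore stands as the only number shown in this assay, the other value being a limit (the limit of > 10000 nM in this assay, at which 1 of the 2 values shown sits). Among the measured compounds shown here, the single measured step, an at least 1000-fold lower number from compound 1 to compound 2 (3.02 log units; beyond the scatter), is large.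

Compound 3, `CC1CC(C(=O)N2CCc3nc(C#Cc4ccccc4)sc3C2)C1`, differs from compound 2 by 3-methylcyclobutyl in place of 2-methylcyclopropyl on a carbonyl carbon. For the measured compounds named here, no measured step compares two different rings on the carbonyl carbon; the one measured step, an at least 1000-fold lower number from compound 1 to compound 2 (3.02 log units; beyond the scatter), only shows that a methyl on the saturated ring matters greatly, and compound 3 keeps a methyl on its ring. A step of moderate size, most likely toward a higher number, is expected in this assay, a 3.2-fold higher number from compound 2 to compound 3 (0.50 log units; beyond the scatter). Compound 3 is estimated at 30 nM, within 5 nM to 300 nM.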

Compound 3, half-maximal effective concentration: 81 nM
Estimate against measurement, compound 3: 2.7-fold (0.43 log units) below; measured number inside the range.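

With the ring on the carbonyl carbon itself changed, this assay shows an 8.6-fold higher number from compound 2 to compound 3 (0.94 log units; beyond the scatter), so exchanging 2-methylcyclopropyl for 3-methylcyclobutyl has a real cost at this position but does not abolish the effect. Against the cyclopropyl of compound 1, the same group gives an at least 120-fold lower number from compound 1 to compound 3 (2.09 log units; beyond the scatter), so a low number here is not confined to the three-membered ring of compound 2. The value of compound 1 is a limit of this assay, not a number, so this step gives only a lower bound on the change: the limit of > 10000 nM in this assay, at which 1 of the 3 values shown sits.

The compounds shown leave open whether a plain cyclobutyl would keep the effect, and so whether the methyl matters on the four-membered ring as it does on the three-membered one. On these data alone, how a cyclopentyl, an isobutyl chain or a ring carrying an amine would read at this position also stays open.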